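A few compounds are considered here, and "the series" means these few. Any claim that something is new, unique, unknown or untested is made for them only; others in the source may bear on it.

Of the compounds shown here, three have so far been tested in a functional assay (Cavia porcellus) with sulfonylurea receptors; K-ATP channels (Homo sapiens) as the target; a lower number here means a stronger inhibitor, a higher number a weaker inhibitor. Compound 1 `CC(O)(C(=O)Nc1cccc(S(=O)(=O)c2ccccc2)c1)C(F)(F)F` gives only a limit there, > 30000 nM, so no number is known for it. Compound 2 `CC(O)(C(=O)Nc1ccc(S(=O)(=O)c2ccccc2)c(O)c1)C(F)(F)F` gives 430 nM. Compound 3 `COc1ccccc1S(=O)(=O)c1ccc(NC(=O)C(C)(O)C(F)(F)F)cc1` gives 1600 nM, the higher of the two numbers, and its gap to compound 2 is beyond the scatter. Compound 4 `CN(c1ccccc1)S(=O)(=O)c1ccc(NC(=O)C(C)(O)C(F)(F)F)cc1` has not yet been measured; it differs from compound 3 by methyl(phenyl)amino in place of 2-methoxyphenyl on a sulfonyl sulfur. Going by the values given here, no pair of measured compounds shares just this change, so there is no direct comparison to lean on. The step from compound 3 to compound 4 is expected to be a 1.6-fold higher number from compound 3 to compound 4 (0.19 log units; within the scatter), a mild weakening that may not exceed the scatter. Compound 4 is therefore estimated at 2500 nM, within a range from 800 nM to 8000 nM.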

Compound 4, half-maximal inhibitory concentration: 2000 nM
For compound 4 the middle estimate is 1.3-fold (0.10 log units) above the measured one; low and high end bracket the measured number.
By their numbers in this assay, from the lowest: compound 2; then compounds 3 and 4 (each within the scatter of the next). At a limit, above all of these: compound 1.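

The swap on the sulfonyl sulfur gives a 1.3-fold higher number from compound 3 to compound 4 (0.10 log units; within the scatter) in this assay, so the two compounds cannot be told apart in this assay. Going by these compounds alone, this is the first sign that this place can hold methyl(phenyl)amino as well as 2-methoxyphenyl, even though the hydrogen-bond acceptor counted in 2-methoxyphenyl is absent from methyl(phenyl)amino. Nothing measured here explains this step.

The compounds shown leave open whether this place needs an aromatic ring at all. A group such as dimethylamino or morpholine on the sulfonyl sulfur would test this.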